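The compounds below may be only part of what the source reports. "The series", "measured", "known", "first", "only" and "open" are said of these compounds alone.

Measured so far:
compound 1, `CCSC[C@@](O)([C@@H](Nc1cc(F)cc2[nH]c(=O)ccc12)c1ccc(OC)c(F)c1Cl)C(F)(F)F`, in a functional assay on THP-1 cells (Homo sapiens) (on this read-out higher numbers stand for larger maximal responses and lower numbers for smaller maximal responses), compound 1 gives 93%;
compound 2, `CCOC[C@@](O)([C@@H](Nc1cc(F)cc2[nH]c(=O)ccc12)c1ccc(OC)c(F)c1Cl)C(F)(F)F`, in this assay compound 2 gives 99%.

Compound 2 sits alongside compound 1, the two values within the usual scatter: a number 6 percentage points higher from compound 1 to compound 2 (within the scatter). Compound 3, `COc1ccc([C@H](Nc2cc(F)cc3[nH]c(=O)ccc23)[C@](O)(CN(C)C)C(F)(F)F)c(Cl)c1F`, has not been measured. It differs from compound 2 by dimethylamino in place of ethoxy on a saturated chain carbon, two bonds along the chain from an oxygen on a saturated carbon. Among the compounds with values here, only one measured step bears on this position, the exchange from compound 1 to compound 2, which stayed within the scatter, and that step swapped one small chain group for another in the same way. No step beyond the scatter is therefore expected in this assay for compound 3, estimated at 95% (range 80% to 105%), a step of a number 4 percentage points lower from compound 2 to compound 3 (within the scatter).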

Compound 3, largest response reached (Emax), in percent of the reference or control that the assay uses in the THP-1 assay: 109%
Compound 3: middle estimate off by 14 percentage points, on the low side, outside the stated range (above it).
By their numbers in the THP-1 assay, from the lowest: compounds 1, 2 and 3 (each within the scatter of the next, the first and the last beyond it).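

Within the data shown here, in the THP-1 assay, dimethylamino on this saturated chain carbon gives a number 10 percentage points higher from compound 2 to compound 3 (within the scatter), while against ethylsulfanyl it gives a number 16 percentage points higher from compound 1 to compound 3 (beyond the scatter), the first step at this position to pass the scatter. The position therefore does respond to the group it carries, although only ethylsulfanyl and dimethylamino can be told apart, with ethoxy within the scatter of both. In a physicochemical assay for lipophilicity (on this read-out higher numbers stand for higher lipophilicity and lower numbers for lower lipophilicity), compound 2 gives 3.8 and compound 3 gives 4.4, so this change also raises lipophilicity: the measured partition coefficient of compound 2, 3.8, and of compound 3, 4.4, a number 0.60 log units higher (beyond the scatter)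

Going by these compounds, whether the larger response follows the amine itself or the lipophilicity stays open, since one pair cannot separate the two. A ring amine such as pyrrolidine, or a carboxylic acid, at this place could help to tell them apart.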